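Ethoxy in place of methoxy on two related cores

A few compounds are considered here, and "the series" means these few. Any claim that something is new, unique, unknown or untested is made for them only; others in the source may bear on it.

Compound 1 `COc1nc(-c2cc3ccccc3o2)cc(-c2ccc(C)cc2)c1C#N` and compound 2 `CCOc1nc(-c2cc3ccccc3o2)cc(-c2ccc(C)cc2)c1C#N` share one core. In a functional assay on aorta (strain Wistar) for inhibition, with Thoracic aorta (Rattus norvegicus) as the target (a lower number here means a stronger inhibitor, a higher number a weaker inhibitor), compound 1 gives 266000 nM and compound 2 gives 290000 nM. The change methyl in place of hydrogen on a saturated chain carbon bound to an oxygen on an aromatic ring produced a 1.1-fold higher number from compound 1 to compound 2 (0.04 log units; within the scatter). Compound 3 `COc1ccc(OC)c(-c2cc(-c3cc4ccccc4o3)nc(OC)c2C#N)c1` gives 246000 nM in this assay; the difference between the core of compound 3 and the core of compound 1 is not broken down here. Compound 4 `CCOc1nc(-c2cc3ccccc3o2)cc(-c2cc(OC)ccc2OC)c1C#N` carries the same change relative to compound 3, namely (methyl in place of hydrogen on a saturated chain carbon bound to an oxygen on an aromatic ring), at a place described in the same words as for compound 1 and compound 2. Because a 1.1-fold higher number from compound 1 to compound 2 (0.04 log units; within the scatter) stayed within the scatter, a step of similar size is expected for compound 4, namely a 1.1-fold higher number from compound 3 to compound 4 (0.03 log units; within the scatter). Compound 4 is thus estimated at 265000 nM, with a range from 170000 nM to 420000 nM, in this assay.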

Compound 4, half-maximal inhibitory concentration: 327000 nM
Beside the measured number, compound 4's estimate is 1.2-fold (0.09 log units) below it; measured number inside the range.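

Ethoxy in place of methoxy gives steps on the two cores that cannot be told apart in this assay: the same change on two cores in this assay, a 1.1-fold higher number (0.04 log units; within the scatter) from compound 1 to compound 2 and a 1.3-fold higher number (0.12 log units; within the scatter) from compound 3 to compound 4, 1.2-fold (0.09 log units) apart, within the scatter of two such steps. The step on the second core is a 1.3-fold higher number from compound 3 to compound 4 (0.12 log units; within the scatter), and 2,5-dimethoxyphenyl in place of 4-methylphenyl on an aromatic carbon gives a 1.1-fold higher number from compound 2 to compound 4 (0.05 log units; within the scatter), so neither change registers here. This supports carrying the ethoxy change between these two cores only; with both steps inside the scatter, it does not show that a change with a real effect would carry over in the same way.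

Still open, as far as these compounds go, is whether a propyl chain on that oxygen, or an amine in place of the ethoxy group, would give a step beyond the scatter in this assay.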